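The compounds below may be only part of what the source reports. "The series", "measured", "known", "first", "only" and "open" are said of these compounds alone.

Measured in a functional assay on Lewis lung carcinoma cells (Mus musculus) for antiproliferative activity, read by MTT assay, with a stated time of 24 h; a higher number here means a weaker inhibitor, a lower number a stronger inhibitor:
Compound 1 `C=CCc1cc(-c2cccc(C(F)(F)F)c2)ccc1O`: 65900 nM
Compound 2 `C=CCc1cc(C=O)c(OCC(=O)OCC)c(-c2ccc(OCC(=O)OCC)c(CC=C)c2)c1`: 26100 nM

Of these two, compound 2 has the lower number, 26100 nM, and the gap to compound 1 lies beyond the usual scatter. Compound 3 `C=CCc1ccc(OCC(=O)OCC)c(-c2ccc(OCC(=O)OCC)c(CC=C)c2)c1` differs from compound 2 in one place: hydrogen in place of formyl on an aromatic carbon. Going by the values given here, no measured pair shows this change, so any expectation is loose. In this assay, a small move toward a higher number is expected, possibly no larger than the scatter: the estimate is a 1.4-fold higher number from compound 2 to compound 3 (0.14 log units; within the scatter). For compound 3 the estimated value is 36000 nM, with an expected range from 13000 nM to 95000 nM.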

Compound 3, half-maximal inhibitory concentration: > 91300 nM
Compound 3 ended at the assay's limit (the forecaster's own chance of this, stated with the estimate: 10%); middle value at least 2.5-fold (0.40 log units) from the limit.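

On the aromatic carbon ortho to a (ethoxycarbonyl)methoxy group, the formyl group makes a difference in this assay: hydrogen in its place gives an at least 3.4-fold higher number from compound 2 to compound 3 (0.54 log units; beyond the scatter). Going by these compounds alone, this is the first single-place comparison here, and it shows that the lower number of compound 2 depends on that formyl group. The reading for compound 3 is a limit of the assay, not a number: the limit of > 91300 nM in this assay, at which 1 of the 3 values shown sits.

As far as these compounds go, the full size of the step therefore stays unknown. From the compounds shown here alone, whether a carboxylic acid or a hydroxymethyl group on this carbon would match formyl also remains open.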